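Compound 2 to compound 3: exchange on a carbonyl carbon

The source may hold more compounds than are shown below. What is called first, only, known or untested is meant among the compounds shown, and "the series" means these compounds.

In a physicochemical assay for solubility (on this read-out lower numbers stand for lower solubility and higher numbers for higher solubility), compound 1 (`CC(C)(C)OC(=O)N1CCC[C@H]1C(=O)N1CCC(NS(=O)(=O)c2cc(S(=O)(=O)c3ccccc3)ccc2C(F)(F)F)CC1`) gives 25000 nM and compound 2 (`CC(C)(C)OC(=O)N1CCC[C@@H]1C(=O)N1CCC(NS(=O)(=O)c2cc(S(=O)(=O)c3ccccc3)ccc2C(F)(F)F)CC1`) gives 25000 nM so that compound 2 stands level with compound 1. Compound 3 (`O=C1CC[C@@H](C(=O)N2CCC(NS(=O)(=O)c3cc(S(=O)(=O)c4ccccc4)ccc3C(F)(F)F)CC2)N1`) carries 5-oxopyrrolidin-2-yl in place of 1-(tert-butoxycarbonyl)pyrrolidin-2-yl on a carbonyl carbon. Going by the values given here, the one measured step shows no change at the digits printed from compound 1 to compound 2 (within the scatter) and concerns configuration only (the fact that compounds 1 and 2 differ only in the configuration as drawn). Among the compounds with values here, no measured step covers an exchange of this group, so the estimate takes compound 2 at 25000 nM as its starting level and carries a wide margin. In this assay no step beyond the scatter is expected, with a 1.2-fold higher number from compound 2 to compound 3 (0.08 log units; within the scatter) as the estimated step. For compound 3 the expected value is 30000 nM with an estimated range of 12000 nM to 80000 nM for this untested exchange.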

Compound 3, solubility: 100000 nM
The estimate for compound 3 lay 3.3-fold (0.52 log units) below the measured number, outside the stated range (above it).
By their numbers in this assay, from the lowest: compounds 1 and 2 (each within the scatter of the next); then compound 3.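

In this assay, going by these compounds alone, the exchange on the carbonyl carbon is the first change to pass the scatter, with a 4.0-fold higher number from compound 2 to compound 3 (0.60 log units; beyond the scatter) and a 4.0-fold higher number from compound 1 to compound 3 (0.60 log units; beyond the scatter) for the same replacement. The step reads alike from both starting compounds, so the drawn configuration of the leaving group shows no weight in this comparison: the fact that compounds 1 and 2 differ only in the configuration as drawn. The entering 5-oxopyrrolidin-2-yl is the smaller group and carries a hydrogen-bond donor that 1-(tert-butoxycarbonyl)pyrrolidin-2-yl lacks, and this single exchange cannot separate those two differences.

Open, on these data alone, is how a plain pyrrolidin-2-yl with a free amine would read at this carbonyl carbon, which would help separate them. Also open, as far as these compounds go, is whether the opposite configuration of the 5-oxopyrrolidin-2-yl group reads level with compound 3, as compound 2 does with compound 1.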